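Demethylation of a Potent Dichloroanisole Ketone

The source may report more compounds than this note shows. Statements on the series, on what has been measured and on what is new or still open speak of the compounds shown alone.

Compound 1 `COc1c(Cl)cc(-c2ccc(C(=O)c3c(Cl)ccc(O)c3F)s2)cc1Cl` is examined in an assay for inhibition of 17-beta-hydroxysteroid dehydrogenase type 1 (Homo sapiens), read by HPLC, in the presence of a further agent that is not named here (on this read-out higher numbers stand for weaker inhibition and lower numbers for stronger inhibition), where compound 1 gives 0.5 nM. This is the lowest of the three numbers available. Compound 2 `CS(=O)(=O)c1cccc(-c2ccc(C(=O)c3cc(F)c(F)c(O)c3F)s2)c1` gives 8 nM in this assay, a gap that lies beyond the scatter of repeated measurement, and compound 3 `NS(=O)(=O)Oc1ccc(-c2ccc(C(=O)c3cc(F)c(F)c(O)c3F)s2)cc1` gives 35 nM, further still from compound 1. Going by the values given here, neither of these two compounds differs from compound 1 in a single place, so no isolated step between measured compounds can be read from them; what they show is that compound 1 stands clearly apart.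

Compound 4 `O=C(c1ccc(-c2cc(Cl)c(O)c(Cl)c2)s1)c1c(Cl)ccc(O)c1F` differs from compound 1 by one change: hydrogen in place of methyl on an oxygen on an aromatic ring, the methoxy group becoming a hydroxy group. Among the compounds with values here, no measured pair shows this particular change, so the size of its effect is open. A step of this kind is expected to be small, at most a modest weakening, and may well stay within the scatter. Compound 4 is therefore expected to give 1 nM in this assay, within a range of 0.25 nM to 4 nM, which would mean a step of a 2.0-fold higher number from compound 1 to compound 4 (0.30 log units; within the scatter).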

Compound 4, half-maximal inhibitory concentration: 3 nM
The estimate for compound 4 lay 3.0-fold (0.48 log units) below the measured number, and the stated range covers the measured number.
By their numbers in this assay, from the lowest: compound 1; then compound 4; then compound 2; then compound 3.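

Going by these compounds alone, on an oxygen on an aromatic ring, hydrogen in place of methyl gives a 6.0-fold higher number from compound 1 to compound 4 (0.78 log units; beyond the scatter) in this assay, the first step in this set that isolates a single change. Within the data shown here, it shows that this position responds to the change from methoxy to hydroxy, with a modest loss of inhibition that lies beyond the scatter, something the earlier compounds, none of them one change away from compound 1, could not show. Nothing available here bears on why the step has this size.

Going by these compounds, it remains open how an ethoxy group or an amine at this place would compare with the methoxy group of compound 1. One pair also cannot tell whether the same change would give a similar step on another core.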